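One More Swap on the Same Chain Carbon

A few compounds are considered here, and "the series" means these few. Any claim that something is new, unique, unknown or untested is made for them only; others in the source may bear on it.

In a physicochemical assay for solubility, read by HPLC, in phosphate buffer, at pH 6.5 (a lower number here means a less soluble compound, a higher number a more soluble compound), compound 1 `COC(=O)C1=C(C)NC(c2nccs2)=NC1(C)c1ccc(F)cc1` gives 22 ug/mL. Compound 2 `COC(=O)C1=C(CN2CCCCC2)NC(c2nccs2)=NC1(C)c1ccc(F)cc1` gives 282 ug/mL and compound 3 `COC(=O)C1=C(CN2CCC(O)C2)NC(c2nccs2)=NC1(C)c1ccc(F)cc1` gives 503 ug/mL, so compound 3 stands level with compound 2 and far above compound 1. Compound 4 `COC(=O)C1=C(CN(C)C2(C(=O)O)CC2)NC(c2nccs2)=NC1(C)c1ccc(F)cc1` keeps the shared core and changes one group: a group of 8 heavy atoms (5 carbon, 1 nitrogen, 2 oxygen; one three-membered non-aromatic ring of carbon only) in place of a group of 6 heavy atoms (4 carbon, 1 nitrogen, 1 oxygen; one five-membered non-aromatic ring with 1 hetero atom), on a saturated chain carbon bound to a double-bonded ring carbon. Within the data shown here, three measured steps concern this same place. Both a 13-fold higher number from compound 1 to compound 2 (1.11 log units; beyond the scatter) and a 23-fold higher number from compound 1 to compound 3 (1.36 log units; beyond the scatter) are large, whereas a 1.8-fold higher number from compound 2 to compound 3 (0.25 log units; within the scatter) stays within the scatter. Among the measured compounds shown here, exchanging one such group for another has therefore moved little so far, though that rests on a single pair, and no measured compound carries the three-membered ring. The step expected in this assay is a 1.6-fold higher number from compound 3 to compound 4 (0.20 log units; within the scatter), not beyond the scatter. The estimated value for compound 4 is 800 ug/mL, with an expected range from 250 ug/mL to 2000 ug/mL.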

Compound 4, solubility: > 510 ug/mL
Compound 4: no number, only a limit; the forecaster's own chance of this, stated with the estimate: 15%; the middle value does not contradict the limit.
By their numbers in this assay, from the lowest: compound 1; then compounds 2 and 3 (each within the scatter of the next). At a limit, above all of these: compound 4.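

In this assay, compound 4 gives a limit and not a number: the limit of > 510 ug/mL in this assay, at which 1 of the 4 values shown sits. The group with the three-membered ring of carbon only thus joins the two earlier groups on this saturated chain carbon in standing clear of compound 1, with an at least 23-fold higher number from compound 1 to compound 4 (1.36 log units; beyond the scatter). Against the other two only floors can be read, an at least 1.0-fold higher number from compound 3 to compound 4 (0.00 log units; that floor lies within the scatter) and an at least 1.8-fold higher number from compound 2 to compound 4 (0.25 log units; that floor lies within the scatter), so no order among these three is settled.

On these data alone, how far the true reading of compound 4 lies past its limit stays open. Also open, as far as these compounds go, is how a morpholin-4-yl group, or a longer chain ending in an amine, would read on this same carbon.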